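Widening the dialkylamino group: compound 2 to compound 3

A few compounds are considered here, and "the series" means these few. Any claim that something is new, unique, unknown or untested is made for them only; others in the source may bear on it.

Compound 1 `CCCCCCOc1c(-c2cc(OC)c(OC)c(OC)c2)oc2ccccc2c1=O` gives 19600 nM in a functional assay on LNCaP cells (Homo sapiens) for antiproliferative activity, read by WST assay, with a stated time of 3 days; on this read-out lower numbers stand for stronger inhibition and higher numbers for weaker inhibition
Compound 2 `CCCN(CCC)CCCCCOc1c(-c2cc(OC)c(OC)c(OC)c2)oc2ccccc2c1=O` gives 7600 nM in this assay

For the measured compounds named here, compound 2 at 7600 nM holds the lower of the two numbers so far. Compound 3 `CCCCCN(CCCCC)CCCCCOc1c(-c2cc(OC)c(OC)c(OC)c2)oc2ccccc2c1=O` differs from compound 2 by dipentylamino in place of dipropylamino on a saturated chain carbon, five bonds along the chain from an oxygen on an aromatic ring and nothing else. Going by the values given here, the one measured step that bears on this is a 2.6-fold lower number from compound 1 to compound 2 (0.41 log units; beyond the scatter) and it is modest. Among the compounds with values here, no measured step alters dipropylamino itself, so in this assay the expectation is a slightly lower number at most, with no step beyond the scatter. The expected change is a 1.3-fold lower number from compound 2 to compound 3 (0.10 log units; within the scatter) and no more. Compound 3 is estimated at 6000 nM with a range from 2400 nM to 15000 nM in this read-out.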

Compound 3, half-maximal inhibitory concentration: 7900 nM
Compound 3: the middle estimate sits 1.3-fold (0.12 log units) below what was measured; measured number inside the range.
By their numbers in this assay, from the lowest: compounds 2 and 3 (each within the scatter of the next); then compound 1.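

In this assay, dipentylamino in place of dipropylamino gives a 1.0-fold higher number from compound 2 to compound 3 (0.02 log units; within the scatter) and so leaves the number unchanged within the scatter, even with the larger dialkylamino group at this place. Set against the plain hexyl chain of compound 1, dipentylamino gives a 2.5-fold lower number from compound 1 to compound 3 (0.39 log units; beyond the scatter) as a modest step, so both dialkylamino groups shown keep the separation from compound 1. Nothing measured accounts for either step.

Still open, going by these compounds, is whether dimethylamino or a cyclic amine such as piperidine or morpholine at this place would keep the number. A shorter or longer chain between the amine and the core also remains untested in the compounds shown.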